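Series notes: ethylsulfonyl replacing propylsulfanyl on the ring carbon

A few compounds are considered here, and "the series" means these few. Any claim that something is new, unique, unknown or untested is made for them only; others in the source may bear on it.

Measured so far:
compound 1 `CCCSc1nnc(COc2cc(C)c3c(C)cc(=O)oc3c2)o1` — > 100000 nM
compound 2 `CCCCCCSc1nnc(COc2cc(C)c3c(C)cc(=O)oc3c2)o1` — > 100000 nM

In a functional assay on MCF7 cells (Homo sapiens) for antiproliferative activity, read by MTT assay, with a stated time of 24 h (a higher number here means a weaker inhibitor, a lower number a stronger inhibitor), compound 1 gives > 100000 nM, which is a limit of the assay and not a number. Compound 2 gives only a limit as well, > 100000 nM. The sole measured step, a step that the two limits leave unreadable from compound 1 to compound 2, therefore cannot be read; both values sit at the limit of > 100000 nM in this assay, at which 2 of the 2 values shown sit, so nothing shown places compound 1 anywhere but at that limit.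

Compound 3 `CCS(=O)(=O)c1nnc(COc2cc(C)c3c(C)cc(=O)oc3c2)o1` differs from compound 1 by ethylsulfonyl in place of propylsulfanyl on an aromatic carbon. Among the measured compounds shown here, no measured step covers a change of this kind, and the one step in hand is unreadable, so no direction or size can be drawn from the data. Compound 3 is expected to give 150000 nM, with a range of 30000 nM to 1000000 nM, most likely again only a limit. This estimate means a step that the limit leaves unreadable from compound 1 to compound 3, an expectation without support from any shown step.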

Compound 3, half-maximal inhibitory concentration: > 100000 nM
Compound 3 gave a limit, no number; the forecaster's own chance of this, stated with the estimate: 80%; the middle value lies beyond the limit too.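

Neither compound 1 to compound 3 nor compound 2 to compound 3 gives a readable step, as all three compounds stand at one limit, not a number: the limit of > 100000 nM in this assay, at which 3 of the 3 values shown sit.

The compounds shown leave open whether any change at this aromatic carbon moves activity on the shared core, and in which direction.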